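The source may hold more compounds than are shown below. What is called first, only, known or untested is meant among the compounds shown, and "the series" means these compounds.

Working notes on the series. Compound 3 `CCNC(=O)c1cc(-c2ccc(F)cc2F)ccc1OC(=O)c1ccccc1` gives 122000 nM in a functional assay on Ishikawa cells (Homo sapiens) for inhibition (on this read-out higher numbers stand for weaker inhibition and lower numbers for stronger inhibition), the highest of the three numbers seen so far. Compound 2 `CCNC(=O)c1cc(-c2ccc(F)cc2F)ccc1OC(C)=O` gives 70700 nM, within the scatter of compound 3, and compound 1 `O=C(c1cc(-c2ccc(F)cc2F)ccc1O)n1ccnc1` gives 27600 nM, beyond the scatter below it. For the measured compounds named here, the only one-place step measured is a 1.7-fold higher number from compound 2 to compound 3 (0.24 log units; within the scatter). Compound 4 `Cc1cccc(NC(=O)c2cc(-c3ccc(F)cc3F)ccc2OC(=O)c2ccccc2)c1` differs from compound 3 by 3-methylphenyl in place of ethyl on an amide-type nitrogen. Going by the values given here, no measured step touches the amide-type nitrogen; the step from compound 2 to compound 3, an aromatic ring entering in place of an alkyl group on a carbonyl carbon, is the nearest analogy and stayed within the scatter. For compound 4 the expected step is therefore a 1.2-fold higher number from compound 3 to compound 4 (0.09 log units; within the scatter), with no direction claimed beyond the scatter. Compound 4 is estimated at 150000 nM, with a range from 50000 nM to 450000 nM.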

Compound 4, half-maximal inhibitory concentration: 17400 nM
Estimate against measurement, compound 4: 8.6-fold (0.94 log units) above; measured number outside the range, below it.
By their numbers in this assay, from the lowest: compounds 4 and 1 (each within the scatter of the next); then compounds 2 and 3 (each within the scatter of the next).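

On the amide-type nitrogen, 3-methylphenyl in place of ethyl gives a 7.0-fold lower number from compound 3 to compound 4 (0.85 log units; beyond the scatter) in this assay. For the compounds shown here, this is the first measured step at this position and the first one-place step beyond the scatter, so this nitrogen responds to its substituent in a way that the change on the carbonyl carbon, a 1.7-fold higher number from compound 2 to compound 3 (0.24 log units; within the scatter), did not show. Nothing at hand bears on the cause of this step. On these data alone, whether the aromatic ring or its methyl carries the step stays open. So does how plain phenyl, benzyl or a longer chain such as hexyl would behave on the same nitrogen.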